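Swapping the sulfonyl aryl group on the indazole core

The compounds below may be only part of what the source reports. "The series", "measured", "known", "first", "only" and "open" are said of these compounds alone.

Of the compounds shown here, two have been measured in a functional assay on HeLa cells for antagonist activity at 5-hydroxytryptamine receptor 6 (Homo sapiens); a higher number here means a weaker inhibitor, a lower number a stronger inhibitor. Compound 1 `CN1CCN(c2ccc3c(c2)c(S(=O)(=O)c2cccc4ccccc24)nn3Cc2ccccc2)CC1` gives 2 nM. Compound 2 `COc1cccc(S(=O)(=O)c2n[nH]c3ccc(N4CCN(C)CC4)cc23)c1` gives 57 nM. Of the two numbers, compound 2 has the higher one; the gap between compound 2 and compound 1 lies well beyond the usual scatter of this assay, so compound 2 is the weaker inhibitor of the pair.

Compound 3 `CN1CCN(c2ccc3[nH]nc(S(=O)(=O)c4ccc(Cl)cc4)c3c2)CC1` has not yet been measured. It differs from compound 2 in one place: 4-chlorophenyl in place of 3-methoxyphenyl on a sulfonyl sulfur. The rest of the shared core, including the methylpiperazine and the unsubstituted indazole nitrogen, is kept.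

Among the measured compounds shown here, no measured pair in this set shows what such a swap on the sulfonyl sulfur does, so the expectation rests on compound 2 alone. Because compound 2 sits at 57 nM, compound 3 is expected to land near that number, and the step from compound 2 to compound 3 is estimated as a 1.6-fold lower number from compound 2 to compound 3 (0.21 log units; within the scatter), with a modest move toward a lower number considered the most likely outcome. For compound 3 the estimate in this assay is 35 nM, with a range from 10 nM to 120 nM.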

Compound 3, half-maximal inhibitory concentration: 108 nM
Beside the measured number, compound 3's estimate is 3.1-fold (0.49 log units) below it; the range from low to high includes it.
By their numbers in this assay, from the lowest: compound 1; then compounds 2 and 3 (each within the scatter of the next).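

In this assay, among the compounds shown here, putting 4-chlorophenyl in place of 3-methoxyphenyl on a sulfonyl sulfur gives a 1.9-fold higher number from compound 2 to compound 3 (0.28 log units; within the scatter), the only step in this set that reports on this position alone. The position therefore accepts this exchange of aryl groups without a change that can be told from the scatter, even though the methoxy oxygen is lost, a chlorine is gained and the substituent's place on the ring differs, so that compound 2 and compound 3 cannot be ranked. No measurement of any property of these groups bears on this result, and the step itself gives no reason for it.

For the compounds shown here, compound 1 differs from compound 2 and from compound 3 in more than one place, so no step to it can be read, and what its other groups contribute stays open. Also open, from the compounds shown here alone, is whether 3-chlorophenyl or 4-methoxyphenyl, which would separate the effect of the substituent from that of its place on the ring, or an aryl group carrying an amine or a carboxylic acid on the sulfonyl sulfur, would produce a step beyond the scatter.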